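Thiourea variant of the diphenylmethyl diazepane urea series

The source may report more compounds than this note shows. Statements on the series, on what has been measured and on what is new or still open speak of the compounds shown alone.

compound 1 `O=C(NC1CCCCC1)N1CCCN(C(c2ccccc2)c2ccccc2)CC1` gives < 10000 nM in an assay on isolated protein for binding affinity to Neuromedin-U receptor 2 (Homo sapiens); a lower number here means a stronger inhibitor, a higher number a weaker inhibitor; this value is a limit of the assay.
compound 2 `CCCCNC(=O)N1CCCN(C(c2ccccc2)c2ccccc2)CC1` gives < 10000 nM in this assay; this value is a limit of the assay.

The step from compound 1 to compound 2 is a step that the two limits leave unreadable from compound 1 to compound 2. Compound 2 therefore stands only at the limit of < 10000 nM in this assay, at which 2 of the 2 values shown sit, without a number of its own. Compound 3 `S=C(NC1CCCCC1)N1CCCN(C(c2ccccc2)c2ccccc2)CC1` carries a group of 9 heavy atoms (7 carbon, 1 nitrogen, 1 sulfur; one six-membered non-aromatic ring of carbon only) in place of a group of 7 heavy atoms (5 carbon, 1 nitrogen, 1 oxygen; no ring), on an amine nitrogen in a ring. Among the compounds with values here, no measured step bears on this change, and the one step recorded is unreadable. Compound 3 is expected to remain within the region the limits mark, estimated at 3000 nM, between 300 nM and 10000 nM. The step from compound 2 to compound 3 is thus expected at a step that the limit leaves unreadable from compound 2 to compound 3.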

Compound 3, inhibition constant: < 10000 nM
Compound 3: a limit, no number; the forecaster's own chance of this, stated with the estimate: 40%; the middle value is on the limit's open side.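

In this assay no step among compound 1, compound 2 and compound 3 can be read, as all three give only a limit: the limit of < 10000 nM in this assay, at which 3 of the 3 values shown sit.

The compounds shown leave open whether butyl in place of cyclohexyl, or sulfur in place of oxygen, changes binding affinity at all.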